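Swapping the alkyne aryl cap for cyclopropyl

The compounds below may be only part of what the source reports. "The series", "measured", "known", "first", "only" and "open" are said of these compounds alone.

Compound 1 `C[C@@H](NC(=O)c1ccc(C#Cc2cc(F)cc(F)c2)cn1)C(C)(C)O` gives 61.6% in a functional assay on HEK293 cells for positive allosteric modulation of metabotropic glutamate receptor 5 (Rattus norvegicus), read by fluorescence and calcium flux; a higher number here means a larger maximal response, a lower number a smaller maximal response.
Compound 2 `C[C@@H](NC(=O)c1ccc(C#Cc2cccnc2)cn1)C(C)(C)O` gives 71.5% in this assay.
Compound 3 `C[C@@H](NC(=O)c1ccc(C#Cc2ccncc2)cn1)C(C)(C)O` gives 66.6% in this assay.

Among these three, compound 1 holds the lowest number, though its steps to the others stay within the scatter: a number 9.9 percentage points higher from compound 1 to compound 2 (within the scatter) and a number 5 percentage points higher from compound 1 to compound 3 (within the scatter). Compound 4 `C[C@@H](NC(=O)c1ccc(C#CC2CC2)cn1)C(C)(C)O` differs from compound 1 in one place: cyclopropyl in place of 3,5-difluorophenyl on a triple-bonded carbon. Among the compounds with values here, the only steps that touch the same position are the two aromatic swaps just named, both within the scatter, and none of them brings in a three-membered non-aromatic ring. Compound 4 is therefore expected to sit near compound 1 in this assay, with no step beyond the scatter, a number 0.4 percentage points higher from compound 1 to compound 4 (within the scatter). The estimate for compound 4 is 62%, with a range from 45% to 80%.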

Compound 4, largest response reached (reported as efficacy), in percent of the reference or control that the assay uses: 63.4%
The estimate for compound 4 lay 1.4 percentage points below the measured number; the measured number falls inside the stated range.
By their numbers in this assay, from the lowest: compounds 1, 4, 3 and 2 (each within the scatter of the next).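

Cyclopropyl, with 3 heavy atoms against the 8 of 3,5-difluorophenyl, can sit on this triple-bonded carbon with no step beyond the scatter in this assay: a number 1.8 percentage points higher from compound 1 to compound 4 (within the scatter), a number 3.2 percentage points lower from compound 3 to compound 4 (within the scatter) and a number 8.1 percentage points lower from compound 2 to compound 4 (within the scatter). Among these four compounds, then, a six-membered aromatic ring at this position is not required for this level of maximal response. Nothing available explains this match.

As far as these compounds go, whether an open chain such as tert-butyl, or an amine such as dimethylaminomethyl, would keep the response at this position remains open.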